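A few compounds are considered here, and "the series" means these few. Any claim that something is new, unique, unknown or untested is made for them only; others in the source may bear on it.

Compound 3 `O=C(O)CC(Cc1nc2cc(C(=O)O)ccc2[nH]1)c1ccc(Cl)cc1` is examined in an assay on isolated protein for inhibition of protein kinase C zeta type (Homo sapiens), read by 33P incorporation, tested at 50 uM (a lower number here means a weaker effect, a higher number a stronger effect of the compound at the concentration tested), where compound 3 gives 0%. It stands level with its two measured neighbours: compound 1 `O=C(O)CC(Cc1nc2cc(Cl)ccc2[nH]1)c1ccc(Cl)cc1` gives 0%, and compound 2 `CCc1ccc2[nH]c(CC(CC(=O)O)c3ccc(Cl)cc3)nc2c1` gives 0%. The steps among these three all stay flat: no change at the digits printed from compound 1 to compound 3 (within the scatter), no change at the digits printed from compound 2 to compound 3 (within the scatter) and no change at the digits printed from compound 1 to compound 2 (within the scatter). Compound 4 `COC(=O)c1ccc2[nH]c(CC(CC(=O)O)c3ccc(Cl)cc3)nc2c1` is the next to be measured; it differs from compound 3 by methyl in place of hydrogen on an oxygen next to a carbonyl group. Within the data shown here, none of the measured steps touches this oxygen next to a carbonyl group; they all concern the aromatic carbon, and each of them lies within the scatter. Among the measured compounds shown here, the record therefore offers no step that points up or down, and the whole series sits at the bottom of the read-out. For compound 4 the step from compound 3 is expected to be a number 2 percentage points higher from compound 3 to compound 4 (within the scatter), nothing beyond the scatter. The value of compound 4 in this assay is estimated at 2%, within a range from 0% to 12%.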

Compound 4, a percentage reported as inhibition, at one concentration (the size of the read-out at that concentration, not a potency): 0%
Compound 4: middle estimate off by 2 percentage points, on the high side; low and high end bracket the measured number.
By their numbers in this assay, from the lowest: compounds 1, 2, 3 and 4 (each within the scatter of the next).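

In this assay, among these compounds, the first change at this oxygen next to a carbonyl group, methyl in place of hydrogen, turns carboxy into methoxycarbonyl and brings no change at the digits printed from compound 3 to compound 4 (within the scatter). Methoxycarbonyl on the aromatic carbon also compares flatly with ethyl, giving no change at the digits printed from compound 2 to compound 4 (within the scatter), and with chloro, giving no change at the digits printed from compound 1 to compound 4 (within the scatter), so all four substituents at this aromatic carbon now sit at the bottom of the read-out, where any weakening would not show. No evidence is available to explain this flat result.

Going by these compounds, whether an amine, an amide or a longer chain at this aromatic carbon would lift the read-out off the bottom remains open. So does whether any group at this position matters while the rest of the shared core stays as it is.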